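The compounds below may be only part of what the source reports. "The series", "measured", "known", "first", "only" and "open" are said of these compounds alone.

Compound 1 `CCCCCCCCC#Cc1cn([C@H]2C[C@H](F)[C@@H](CO)O2)c(=O)[nH]c1=O` gives, in an ADME assay on Vero cells (Homo sapiens) for cytotoxicity against Vero (Chlorocebus sabaeus), read by MTT assay (a lower number here means that less compound is tolerated, a higher number that more compound is tolerated), the limit > 100 ug/mL.
Compound 2 `CCCCCCCCCCCC#Cc1cn([C@H]2C[C@H](F)[C@@H](CO)O2)c(=O)[nH]c1=O` gives in this assay the limit > 100 ug/mL.
Compound 3 `CCCCCCCCCCCC#Cc1cn([C@H]2CC[C@@H](CO)O2)c(=O)[nH]c1=O` gives in this assay the limit > 100 ug/mL.

Among the measured compounds shown here, compound 2 therefore stands where every value so far stands, at the limit of this assay, and nothing finer is known about it: the limit of > 100 ug/mL in this assay, at which 3 of the 3 values shown sit. Compound 4 `CCCCCCCCCCC#Cc1cn([C@H]2C[C@H](F)[C@@H](CO)O2)c(=O)[nH]c1=O` differs from compound 2 by one change, (hydrogen in place of methyl on a saturated chain carbon, ten or more bonds along the chain from a triple-bonded carbon), that is, a shortening of the chain by one carbon at its far end. For the measured compounds named here, two measured steps touch the same region of the molecule. The chain lengthening a step that the two limits leave unreadable from compound 1 to compound 2 and the change at the sugar a step that the two limits leave unreadable from compound 2 to compound 3 are both steps between two limits, so neither gives a readable size. Compound 4 is thus expected to stay at the limit as well, with no step beyond the scatter foreseen; its estimated value is 150 ug/mL, within 80 ug/mL to 400 ug/mL. The step expected from compound 2 to compound 4 is a step that the limit leaves unreadable from compound 2 to compound 4.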

Compound 4, half-maximal cytotoxic concentration: > 100 ug/mL
Compound 4 gave a limit, no number (the forecaster's own chance of this, stated with the estimate: 85%); the middle value is on the limit's open side.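

Compound 4 gives a limit, as do compound 1 and compound 2, so the steps from compound 2 to compound 4 and from compound 1 to compound 4 cannot be read. The compounds shown leave open what actual value any of them has in this assay, and so whether chain length or the fluoro group matters there: the limit of > 100 ug/mL in this assay, at which 4 of the 4 values shown sit.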